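Chloro in place of methyl: compound 2 to compound 3

This account rests on a few compounds, and the source may have more. Where it says the series, first, only, none or still open, it means among the compounds named here.

Compound 1 `O=C(Nc1cc(-c2ccccc2)nn1-c1ccccc1)c1ccc(F)cc1` and compound 2 `Cc1ccc(C(=O)Nc2cc(-c3ccccc3)nn2-c2ccccc2)cc1` share one core and differ only in a single group on an aromatic ring. In an assay on CHO cells with metabotropic glutamate receptor 5 (Homo sapiens) as the target (on this read-out higher numbers stand for an effect only at larger amounts of compound and lower numbers for an effect already at smaller amounts), compound 1 gives 30 nM and compound 2 gives 30 nM; the step of no change at the digits printed from compound 1 to compound 2 (within the scatter), methyl in place of fluoro on an aromatic carbon, leaves the read-out unchanged within the scatter. Compound 2 thus stands level with compound 1 at the digits shown, with no measured step beyond the scatter anywhere in the pair.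

Compound 3 `O=C(Nc1cc(-c2ccccc2)nn1-c1ccccc1)c1ccc(Cl)cc1` is the next member: chloro in place of methyl on an aromatic carbon. Among the measured compounds shown here, the only step bearing on this place is no change at the digits printed from compound 1 to compound 2 (within the scatter), which was flat; two different groups at the same place gave the same number. Chloro is a third group at that place, and nothing measured points to a move in either direction. Compound 3 is therefore expected to sit at about the same level, with the step of no change at the digits printed from compound 2 to compound 3 (within the scatter) expected to stay within the scatter. The estimate for compound 3 in this assay is 30 nM, with a range from 12 nM to 75 nM.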

Compound 3, half-maximal effective concentration: 20 nM
Estimate against measurement, compound 3: 1.5-fold (0.18 log units) above; the measured number falls inside the stated range.
By their numbers in this assay, from the lowest: compounds 3, 1 and 2 (each within the scatter of the next).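

In this assay chloro on this aromatic carbon, para to a large group, gives a 1.5-fold lower number from compound 2 to compound 3 (0.18 log units; within the scatter) when it replaces methyl and a 1.5-fold lower number from compound 1 to compound 3 (0.18 log units; within the scatter) when it replaces fluoro on the same position of the shared core. The earlier pair set only fluoro against methyl, whereas the series now holds three groups at this place, and every step among compounds 1, 2 and 3 lies within the scatter. Exchange among fluoro, methyl and chloro at this position therefore gives no read-out difference that can be told from the scatter, and nothing at hand explains why these groups read alike.

The compounds shown leave open whether this flat reading extends to groups of another kind at the same place, such as an amine, a carboxylic acid, a methoxy group or a longer chain. They also leave open whether any other place on the shared core is as indifferent to exchange as this one, since all three compounds differ at this single position.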